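Anilino versus piperidinyl on the shared core: activity notes

A few compounds are considered here, and "the series" means these few. Any claim that something is new, unique, unknown or untested is made for them only; others in the source may bear on it.

Measured so far:
compound 1, `Nc1ccccc1NC(=O)c1ccc(Cn2cnc3c(Nc4ccccc4)nc(Cl)nc32)cc1`, 77.8%;
compound 2, `CC1CCN(c2nc(Cl)nc3c2ncn3Cc2ccc(C(=O)Nc3ccccc3N)cc2)CC1`, 40.9%.

In a functional assay on NCI-H460 cells (Homo sapiens) for antiproliferative activity, read by CCK-8 assay, with a stated time of 72 h, tested at 8 uM (a higher number here means a stronger effect of the compound at the concentration tested, a lower number a weaker effect), compound 2 stands lowest of the two numbers; compound 1 is its nearest neighbour and lies higher by a step beyond the scatter. Among the compounds with values here, the one measured step, a number 36.9 percentage points lower from compound 1 to compound 2 (beyond the scatter), was large. Compound 3, `Nc1ccccc1NC(=O)c1ccc(Cn2cnc3c(Nc4cccc(Cl)c4)nc(Cl)nc32)cc1`, reverses the type of that change: (3-chlorophenyl)amino in place of 4-methylpiperidin-1-yl on an aromatic carbon. Because a number 36.9 percentage points lower from compound 1 to compound 2 (beyond the scatter), a large rise in the other direction is expected here, a number 34.1 percentage points higher from compound 2 to compound 3 (beyond the scatter), bringing compound 3 near compound 1. Compound 3 is therefore estimated at 75%, range 55% to 90%.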

Compound 3, a percentage reported as inhibition, at one concentration (the size of the read-out at that concentration, not a potency): 67%
The estimate for compound 3 lay 8 percentage points above the measured number; measured number inside the range.
By their numbers in this assay, from the lowest: compound 2; then compound 3; then compound 1.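

In this assay, a second arylamino group at this carbon also stands clear of 4-methylpiperidin-1-yl (a number 26.1 percentage points higher from compound 2 to compound 3 (beyond the scatter)), so the gap no longer rests on the anilino group of compound 1 alone. The added chloro on that aromatic ring does not leave the read-out unchanged (a number 10.8 percentage points lower from compound 1 to compound 3 (beyond the scatter)), and (3-chlorophenyl)amino recovers only part of the gap. Nothing at hand accounts for either step. Still open, from the compounds shown here alone, is whether a methoxy or fluoro group on the same ring would give a similar step, and whether a morpholin-4-yl group would fall near compound 2.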